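The compounds below may be only part of what the source reports. "The series", "measured", "known", "first", "only" and "open" are said of these compounds alone.

Measured so far:
- compound 1, `CCN1CCN(c2cc(C)c3cc(NC(=O)c4ccccc4)ccc3n2)CC1`: 14200 nM
- compound 2, `Cc1cc(NCCN2CCCC2)nc2ccc(NC(=O)c3ccc(Cl)c(Cl)c3)cc12`: 1280 nM

Both compounds were tested in a functional assay on MCF7 cells (Homo sapiens) for antiproliferative activity, read by MTT assay, with a stated time of 72 h; on this read-out higher numbers stand for weaker inhibition and lower numbers for stronger inhibition. For the measured compounds named here, compound 1 gives 14200 nM, the highest of the two numbers, and the only other measured compound, compound 2, gives 1280 nM. Going by the values given here, the two differ in more than one place, so their values say only that compound 2 inhibits growth more strongly than compound 1, and nothing about any single change.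

Compound 3, `CCN1CCN(c2cc(C)c3cc(NC(=O)c4ccccc4OC)ccc3n2)CC1`, has not yet been measured. It differs from compound 1 in one place: methoxy in place of hydrogen on an aromatic carbon. Among the compounds with values here, no measured pair shows what this particular change does here, so there is no step of this kind to lean on.

Given that gap, the expectation for compound 3 is a step of modest size, most likely within the scatter or a small move toward stronger inhibition, a 1.4-fold lower number from compound 1 to compound 3 (0.15 log units; within the scatter). Compound 3 is therefore expected to give about 10000 nM, with a range from 4000 nM to 30000 nM.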

Compound 3, half-maximal inhibitory concentration: 13200 nM
Estimate against measurement, compound 3: 1.3-fold (0.12 log units) below, within the range that was stated.
By their numbers in this assay, from the lowest: compound 2; then compounds 3 and 1 (each within the scatter of the next).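

In this assay, methoxy in place of hydrogen on an aromatic carbon, ortho to a large group, gives (a 1.1-fold lower number from compound 1 to compound 3 (0.03 log units; within the scatter)), so compound 1 and compound 3 cannot be told apart on this read-out. For the compounds shown here, this is the first comparison here that isolates a single change, and it shows that going from benzoyl to (2-methoxyphenyl)carbonyl, which adds 2 heavy atoms and 1 hydrogen-bond acceptor, leaves the measured inhibition of cell growth unchanged within the usual scatter of repeat measurements. No other measurement bears on this result, so the data give no explanation for the absence of a measurable step.

From the compounds shown here alone, this single step covers only methoxy at this one place, so it remains open whether a larger or differently charged group there, such as an amine, a carboxylic acid or a longer chain like butoxy, would also leave the value in place. Compound 2 still differs from compound 1 in more than one place, so the step here does not show which of those differences goes with its lower number.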